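A Pyrazole in Place of the Fluorophenyl Group

A few compounds are considered here, and "the series" means these few. Any claim that something is new, unique, unknown or untested is made for them only; others in the source may bear on it.

Of the compounds shown here, three sharing one core have been measured in a functional assay on HCT-116 cells (Homo sapiens) for antiproliferative activity, read by sulforhodamine B assay, with a stated time of 72 h; a lower number here means a stronger inhibitor, a higher number a weaker inhibitor. Compound 1 `COc1ncc(-c2ccc3ncnc(Nc4ccc(OCCO)c(F)c4)c3c2)cc1NS(=O)(=O)c1ccc(F)cc1F` gives 9160 nM, the highest of the three numbers. Compound 2 `COc1ncc(-c2ccc3ncnc(Nc4cnn(CCCO)c4)c3c2)cc1NS(C)(=O)=O` gives 1420 nM, and compound 3 `COc1ncc(-c2ccc3ncnc(Nc4ccc(OCCO)cc4)c3c2)cc1NS(=O)(=O)c1ccc(F)cc1F` gives 1060 nM. Among the compounds with values here, the only single-point step among them runs an 8.6-fold lower number from compound 1 to compound 3 (0.94 log units; beyond the scatter), so removing the fluoro alone already moves the number a long way down from compound 1.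

The step to compound 4 `COC(=O)Cn1cc(Nc2ncnc3ccc(-c4cnc(OC)c(NS(=O)(=O)c5ccc(F)cc5F)c4)cc23)cn1` is larger: 1-((methoxycarbonyl)methyl)-1H-pyrazol-4-yl in place of 3-fluoro-4-(2-hydroxyethoxy)phenyl on a nitrogen on an aromatic ring. Within the data shown here, no measured pair shows this exact swap, so the step from compound 1 to compound 3 is the nearest guide, and compound 2, which also carries a pyrazol-4-yl on that nitrogen though with a different sulfonamide, gives a second point of reference with its value of 1420 nM.

Compound 4 is therefore expected to show a lower number than compound 1, by about a 6.1-fold lower number from compound 1 to compound 4 (0.79 log units; beyond the scatter). The estimate for compound 4 is 1500 nM, with a range from 400 nM to 6000 nM.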

Compound 4, half-maximal inhibitory concentration: 1260 nM
Compound 4: the middle estimate sits 1.2-fold (0.08 log units) above what was measured, and the stated range covers the measured number.
By their numbers in this assay, from the lowest: compounds 3, 4 and 2 (each within the scatter of the next); then compound 1.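

In this assay, the group on this nitrogen need not be a six-membered aromatic ring of carbon only: 1-((methoxycarbonyl)methyl)-1H-pyrazol-4-yl in place of 3-fluoro-4-(2-hydroxyethoxy)phenyl gives a 7.3-fold lower number from compound 1 to compound 4 (0.86 log units; beyond the scatter). Set against 4-(2-hydroxyethoxy)phenyl, the same pyrazole gives a 1.2-fold higher number from compound 3 to compound 4 (0.08 log units; within the scatter), so these two very different groups cannot be told apart here, even though the pyrazole group has 0 hydrogen-bond donors and the group it replaces has 1. Nothing measured here accounts for this match.

As far as these compounds go, what remains open is how much of the result comes from the pyrazole ring and how much from its side chain. A carboxylic acid or a primary amide in place of the methoxycarbonyl group, or a longer chain between that group and the pyrazole, would help separate the two.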